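This account rests on a few compounds, and the source may have more. Where it says the series, first, only, none or still open, it means among the compounds named here.

The measured compounds in a functional assay on MIA PaCa-2 cells (Homo sapiens) for antiproliferative activity, read by sulforhodamine B assay, with a stated time of 48 h (on this read-out higher numbers stand for weaker inhibition and lower numbers for stronger inhibition), are:

compound 1, `COc1cc(OC)c2sc(-c3ccc(N/C=C\C(=O)c4ccc(OC)c([N+](=O)[O-])c4)c(C)c3)nc2c1`, with 13900 nM
compound 2, `COc1ccc(C(=O)/C=C\Nc2ccc(-c3nc4cc(OC)c(OC)c(OC)c4s3)cc2)cc1[N+](=O)[O-]`, with 15900 nM
compound 3, `COc1cc(OC)c2sc(-c3ccc(N/C=C\C(=O)c4ccc(OC)c(F)c4)c(C)c3)nc2c1`, with 16300 nM

Compound 2 carries a core that differs from that of compound 1; the difference between the two cores is not broken down here. Compound 3 is obtained from compound 1 by a single change, (fluoro in place of nitro on an aromatic carbon), and in this assay this change produced a 1.2-fold higher number from compound 1 to compound 3 (0.07 log units; within the scatter). Compound 4, `COc1ccc(C(=O)/C=C\Nc2ccc(-c3nc4cc(OC)c(OC)c(OC)c4s3)cc2)cc1F`, is still unmeasured; it stands to compound 2 as compound 3 stands to compound 1, with the same change made at the same place, (fluoro in place of nitro on an aromatic carbon). Since the earlier step stayed within the scatter, compound 4 is expected to show a 1.1-fold higher number from compound 2 to compound 4 (0.05 log units; within the scatter) in this assay, because a 1.2-fold higher number from compound 1 to compound 3 (0.07 log units; within the scatter) gave no real movement. The estimate for compound 4 is therefore 18000 nM, with a likely range from 9000 nM to 36000 nM.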

Compound 4, half-maximal inhibitory concentration: 19400 nM
Beside the measured number, compound 4's estimate is 1.1-fold (0.03 log units) below it; low and high end bracket the measured number.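

In this assay, fluoro in place of nitro on an aromatic carbon gives a 1.2-fold higher number from compound 2 to compound 4 (0.09 log units; within the scatter), so on the core of compound 2 the swap produces no real movement. Set beside the earlier step, the swap reads alike on both cores: the same change on two cores in this assay, a 1.2-fold higher number (0.07 log units; within the scatter) from compound 1 to compound 3 and a 1.2-fold higher number (0.09 log units; within the scatter) from compound 2 to compound 4, 1.0-fold (0.02 log units) apart, within the scatter of two such steps. This shows that the two steps agree while both stay within the scatter, but it does not show that the swap would read the same on any other core, and it gives no reason for the agreement.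

The compounds shown leave open whether an amine or a carboxylic acid on that aromatic carbon would move the number in this assay. Going by these compounds, a longer chain in place of the methoxy group on that ring also remains open.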